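A few compounds are considered here, and "the series" means these few. Any claim that something is new, unique, unknown or untested is made for them only; others in the source may bear on it.

Of the compounds shown here, three sharing one core have been measured in an in vitro ADME assay on microsomes from liver (Homo sapiens) for metabolic stability, tested at 5 uM; a lower number here means that the compound disappears faster, a higher number that the compound lasts longer. Compound 1 (`CC(C)CCn1nc(CC2CCC2)c(O)c(C2=NS(=O)(=O)c3cc(NS(C)(=O)=O)ccc3N2)c1=O`) gives 0.417 h. Compound 2 (`CCC(C)(C)c1nn(CCC(C)C)c(=O)c(C2=NS(=O)(=O)c3cc(NS(C)(=O)=O)ccc3N2)c1O`) gives 0.1 h. Compound 3 (`CC(C)(C)CCn1nc(-c2cccs2)c(O)c(C2=NS(=O)(=O)c3cc(NS(C)(=O)=O)ccc3N2)c1=O`) reads > 1 h, which is a limit of the assay and not a number. As far as these compounds go, it is the only one of the three that stands at this limit (the limit of > 1 h in this assay, at which 1 of the 3 values shown sits), so its true half-life is unknown.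

Compound 4 (`CCC(C)CCn1nc(-c2cccs2)c(O)c(C2=NS(=O)(=O)c3cc(NS(C)(=O)=O)ccc3N2)c1=O`) has the same atoms as compound 3, joined differently: sec-butyl in place of tert-butyl on a saturated chain carbon, two bonds along the chain from an aromatic nitrogen. Put another way, 3,3-dimethylbutyl becomes 3-methylpentyl, with sec-butyl in place of tert-butyl on a saturated chain carbon, two bonds along the chain from an aromatic nitrogen.

Among the measured compounds shown here, no measured step touches this chain. The nearest evidence is a 4.2-fold lower number from compound 1 to compound 2 (0.62 log units; beyond the scatter), a change elsewhere on the molecule, on an aromatic carbon, so it bears only loosely. It does show that exchanging one all-carbon group for another can move the half-life beyond the scatter. Taking that step as the only guide to size, a modest fall is expected in this assay rather than no change. The estimated step is an at least 1.6-fold lower number from compound 3 to compound 4 (0.22 log units; that floor lies within the scatter). Compound 4 is expected at 0.6 h, with an estimated range of 0.25 h to 1.2 h.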

Compound 4, half-life: > 1 h
Compound 4: only a limit was reported; the forecaster's own chance of this, stated with the estimate: 30%; at least 1.6-fold (0.22 log units) between middle value and limit.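

In this assay compound 4 reads > 1 h and this is a limit of the assay, not a number. Among the compounds shown here, compound 3 stands at the same limit, so no step between compound 3 and compound 4 can be read: the limit of > 1 h in this assay, at which 2 of the 4 values shown sit. As far as these compounds go, what stays open is how far the true half-lives of compound 3 and compound 4 lie past that limit, and whether they differ at all.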